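This account rests on a few compounds, and the source may have more. Where it says the series, first, only, none or still open, it means among the compounds named here.

Compound 3 `C=CC1=C(C(=O)NCC(C)C)C(c2ccc(Cl)c(Cl)c2)OC1` carries an isobutyl group on its amide nitrogen. Among the compounds with values here, in a functional assay on HeLa cells (Homo sapiens) for cytotoxicity, read by MTT assay, with a stated time of 24 h (on this read-out higher numbers stand for weaker inhibition and lower numbers for stronger inhibition), compound 3 gives 60100 nM, the only outright number among the three values measured. Compound 1 `C=CC1=C(C(=O)NCCCCC)C(c2ccc(Cl)c(Cl)c2)OC1` reaches only a limit in this assay, > 100000 nM. Compound 2 `C=CC1=C(C(=O)Nc2ccccc2OC)C(c2ccc(F)cc2)OC1`, the other bearer of a 2-methoxyphenyl amide, likewise reaches only a limit, > 100000 nM. Within the data shown here, the single measured step, an at least 1.6-fold lower number from compound 1 to compound 3 (0.22 log units; that floor lies within the scatter), lies within the scatter, so it says little about how the amide substituent matters. Compound 4 `C=CC1=C(C(=O)Nc2ccccc2OC)C(c2ccc(Cl)c(Cl)c2)OC1` arises when (2-methoxyphenyl in place of isobutyl on an amide-type nitrogen). Among the measured compounds shown here, no measured step covers this exchange directly; what the data offer is that compound 2 sits at the limit with the same 2-methoxyphenyl amide, and that (the limit of > 100000 nM in this assay, at which 2 of the 3 values shown sit). Compound 4 is therefore expected to move back toward that limit, a change estimated as a 1.7-fold higher number from compound 3 to compound 4 (0.22 log units; within the scatter). Compound 4 is expected to give about 100000 nM, within a range from 40000 nM to 300000 nM, with a fair chance that this assay again reports only a limit and no number.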

Compound 4, half-maximal inhibitory concentration: > 100000 nM
Compound 4 ended at the assay's limit; the forecaster's own chance of this, stated with the estimate: 60%; the middle value lies on the limit itself.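

The step of an at least 1.6-fold higher number from compound 3 to compound 4 (0.22 log units; that floor lies within the scatter) gives a direct reading in this assay for the exchange of isobutyl for 2-methoxyphenyl on the amide-type nitrogen, with the 3,4-dichlorophenyl group held constant. It is only a floor, so it establishes no change beyond the scatter, but it shows that the 2-methoxyphenyl amide also yields no outright number when paired with 3,4-dichlorophenyl rather than the 4-fluorophenyl of compound 2. The steps reaching compound 4 from compound 1 and from compound 2 join two limits and cannot be read, and the value of compound 4 is itself a limit, which adds to the count at that limit: the limit of > 100000 nM in this assay, at which 3 of the 4 values shown sit.

The compounds shown leave open whether an amine or a carboxylic acid on the amide-type nitrogen would give a number clearly different from the one for compound 3 at 60100 nM in this series. They also leave open whether a morpholine ring or a simple phenyl group in that place would give an outright number at all.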